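This account rests on a few compounds, and the source may have more. Where it says the series, first, only, none or still open, it means among the compounds named here.

Measured so far:
- compound 1 `C/N=C(/S)C1=CC(C)(C)Oc2ccc([N+](=O)[O-])cc21`: 1.35 nM
- compound 2 `C/N=C(/S)C1=CC(C)(CF)Oc2ccc([N+](=O)[O-])cc21`: 1.62 nM
- compound 3 `C/N=C(/S)C1=CC(C)(C(F)(F)F)Oc2ccc([N+](=O)[O-])cc21`: 0.302 nM

In a functional assay (aorta) with Rattus norvegicus as the target (a higher number here means that more compound is needed for the effect, a lower number that less compound is needed), compound 3 has the lowest number of the three, at 0.302 nM, and its steps to both other compounds lie beyond the scatter. The next compound in view is compound 4 `C/N=C(/S)C1=CC(C(F)(F)F)(C(F)(F)F)Oc2ccc([N+](=O)[O-])cc21`, which differs from compound 3 by trifluoromethyl in place of methyl on a saturated ring carbon.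

Among the measured compounds shown here, the closest precedent is the same replacement in a 4.5-fold lower number from compound 1 to compound 3 (0.65 log units; beyond the scatter), a modest step beyond the scatter. The replacement of fluoromethyl by trifluoromethyl points the same way, with a 5.4-fold lower number from compound 2 to compound 3 (0.73 log units; beyond the scatter), also modest. A single fluoro in place of hydrogen gave a 1.2-fold higher number from compound 1 to compound 2 (0.08 log units; within the scatter), so that step shows no change to build on.

For the measured compounds named here, no measured compound carries two trifluoromethyl groups, so the second replacement may not repeat the first in full. A modest step towards a lower number is expected in this assay, somewhat smaller than the precedent. The expected step is a 2.5-fold lower number from compound 3 to compound 4 (0.40 log units; beyond the scatter). The estimate for compound 4 is 0.12 nM, with an expected range of 0.03 nM to 0.6 nM.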

Compound 4, half-maximal effective concentration: 0.631 nM
Compound 4: middle estimate off by 5.3-fold (0.72 log units), on the low side, and the stated range ends below it.
By their numbers in this assay, from the lowest: compound 3; then compound 4; then compounds 1 and 2 (each within the scatter of the next).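

In this assay, trifluoromethyl in place of methyl on this saturated ring carbon has no fixed direction: with a methyl as the remaining group on that carbon the replacement gives a 4.5-fold lower number from compound 1 to compound 3 (0.65 log units; beyond the scatter), whereas with a trifluoromethyl as the remaining group it gives a 2.1-fold higher number from compound 3 to compound 4 (0.32 log units; beyond the scatter). The outcome of this change therefore depends on the other group on the same carbon, so the step from one compound pair cannot be carried over to the other, and the mixed methyl and trifluoromethyl pattern of compound 3 gives the lowest number of the four, with its steps to all three others beyond the scatter. Nothing available accounts for this reversal.

Still open is whether the reversal is specific to trifluoromethyl, as this carbon is shown carrying only methyl, fluoromethyl and trifluoromethyl groups; difluoromethyl or ethyl would test this in the same setting. On these data alone, it is also open whether the same reversal would hold with a nitrile in place of the nitro group on the shared core.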